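Removing the methoxy group from compound 3

The source may report more compounds than this note shows. Statements on the series, on what has been measured and on what is new or still open speak of the compounds shown alone.

Going by the values given here, compound 3 `COc1ccc(C)cc1NC(=O)CSc1nnc(-c2ccoc2C)n1Cc1ccco1` gives 15.9 nM in a functional assay on CHO cells for antagonist activity at Orexin receptor type 2 (Homo sapiens), read by FLIPR and calcium flux (on this read-out lower numbers stand for stronger inhibition and higher numbers for weaker inhibition), the lowest number among the compounds measured so far, while compound 1 `Cc1ccc(C)c(NC(=O)CSc2nnc(-c3ccoc3C)n2Cc2ccco2)c1` gives 398 nM. Compound 2 `Cc1cccc(NC(=O)CSc2nnc(-c3ccoc3C)n2Cc2ccco2)c1C` reaches only the limit of > 15800 nM in this assay, at which 1 of the 3 values shown sits, and is recorded as > 15800 nM. Compound 4 `Cc1cccc(NC(=O)CSc2nnc(-c3ccoc3C)n2Cc2ccco2)c1` differs from compound 3 in one place: hydrogen in place of methoxy on an aromatic carbon. Among the compounds with values here, the one measured step that bears on this position is a 25-fold lower number from compound 1 to compound 3 (1.40 log units; beyond the scatter), a large drop when methoxy took the place of methyl; the change to compound 4 removes the methoxy altogether. A large rise in the number is therefore expected, estimated as a 50-fold higher number from compound 3 to compound 4 (1.70 log units; beyond the scatter). Compound 4 is expected to give 800 nM, within a range from 150 nM to 5000 nM.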

Compound 4, inhibition constant: 50.1 nM
The estimate for compound 4 lay 16-fold (1.20 log units) above the measured number; the whole stated range lies above it.
By their numbers in this assay, from the lowest: compound 3; then compound 4; then compound 1. At a limit, above all of these: compound 2.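

The methoxy group on this carbon, ortho to a large group, turns out to be worth little compared with hydrogen: a 3.2-fold higher number from compound 3 to compound 4 (0.50 log units; beyond the scatter). The methyl group is what raises the number, since hydrogen in its place gives a 7.9-fold lower number from compound 1 to compound 4 (0.90 log units; beyond the scatter) and an at least 310-fold lower number from compound 2 to compound 4 (2.49 log units; beyond the scatter). That second step starts from a limit and gives only a bound: the limit of > 15800 nM in this assay, at which 1 of the 4 values shown sits.

Among hydrogen, methoxy and methyl, only methoxy gives a lower number than hydrogen here. Going by these compounds, whether ethoxy, hydroxyl or chlorine on this carbon would do the same remains open.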